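From Compound 2 to Compound 3: An Expected Step

The compounds below may be only part of what the source reports. "The series", "measured", "known", "first", "only" and "open" are said of these compounds alone.

Compound 2 `O=C(CCCCCc1cn(-c2ccccc2-c2ccccc2)nn1)NCc1cccnc1` stands lowest of the two numbers measured in a functional assay on SH-SY5Y cells (Homo sapiens) for cytotoxicity, read by MTT assay, with a stated time of 48 h, tested at 1 uM (a lower number here means a stronger effect, a higher number a weaker effect of the compound at the concentration tested), giving 13.4%. Within the data shown here, its only neighbour, compound 1 `O=C(CCc1cccnc1)NCCCCCc1cn(-c2ccccc2-c2ccccc2)nn1`, gives 54% in this assay, and the single step on record, a number 40.6 percentage points lower from compound 1 to compound 2 (beyond the scatter), shows how much the two differ. Compound 3 `O=C(Cc1cccnc1)NCCCCCc1cn(-c2ccccc2-c2ccccc2)nn1` has not yet been measured. It differs from compound 2 as follows: (((pyridin-3-yl)methyl)carbonyl)amino in place of ((pyridin-3-yl)methyl)carbamoyl on a saturated chain carbon, five bonds along the chain from an aromatic carbon. The group entering compound 3 is of the same kind as the ((2-(pyridin-3-yl)ethyl)carbonyl)amino group of compound 1, only with one chain carbon fewer, so the step from compound 1 to compound 2 bears on this change in reverse. On that basis compound 3 is expected to move back toward compound 1, with a step of a number 31.6 percentage points higher from compound 2 to compound 3 (beyond the scatter) in this assay that is expected to lie beyond the scatter. The estimate for compound 3 in this assay is 45%, with a range from 20% to 70%.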

Compound 3, a percentage reported as activity, at one concentration (the size of the read-out at that concentration, not a potency): 99%
The estimate for compound 3 lay 54 percentage points below the measured number, outside the stated range (above it).
By their numbers in this assay, from the lowest: compound 2; then compound 1; then compound 3.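

With the atoms of the group unchanged and only their order along the chain reversed, this assay shows a number 85.6 percentage points higher from compound 2 to compound 3 (beyond the scatter), so the direction of the link at this place on the chain carries a large difference on its own. With that direction held, pyridin-3-yl in place of (pyridin-3-yl)methyl on the saturated chain carbon bound to a carbonyl carbon gives a number 45 percentage points higher from compound 1 to compound 3 (beyond the scatter), so the length on the pyridine side also counts, and the shorter group moves the number further from that of compound 2. Among these three compounds, the strongest effect at the concentration tested belongs to the carbamoyl form, compound 2.

Going by these compounds, it remains open how a longer chain between the carbamoyl group and the pyridine, or a simple amine in place of the amide link, would read. Nothing on hand accounts for these steps.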